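The source may report more compounds than this note shows. Statements on the series, on what has been measured and on what is new or still open speak of the compounds shown alone.

Working notes on the series. Three esters of the shared core have been measured in a functional assay on Bel-7402 cells (Homo sapiens) for cytotoxicity, read by MTT assay, with a stated time of 72 h; on this read-out lower numbers stand for stronger inhibition and higher numbers for weaker inhibition: compound 1 `C=C1C(=O)[C@@]23C(=O)OC[C@]4(C(=O)CCC(C)(C)[C@H]4C=O)[C@@H]2CC[C@@H]1[C@H]3OC(C)=O` gives 1730 nM, compound 2 `C=C1C(=O)[C@@]23C(=O)OC[C@]4(C(=O)CCC(C)(C)[C@H]4C=O)[C@@H]2CC[C@@H]1[C@H]3OC(=O)CC` gives 1650 nM, and compound 3 `C=C1C(=O)[C@@]23C(=O)OC[C@]4(C(=O)CCC(C)(C)[C@H]4C=O)[C@@H]2CC[C@@H]1[C@H]3OC(=O)c1ccc([N+](=O)[O-])cc1` gives 3300 nM. Compound 3 stands within the scatter of both others, with a 1.9-fold higher number from compound 1 to compound 3 (0.28 log units; within the scatter) and a 2.0-fold higher number from compound 2 to compound 3 (0.30 log units; within the scatter). The alkyl change is equally small, with a 1.0-fold lower number from compound 1 to compound 2 (0.02 log units; within the scatter).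

Compound 4 `C=C1C(=O)[C@@]23C(=O)OC[C@]4(C(=O)CCC(C)(C)[C@H]4C=O)[C@@H]2CC[C@@H]1[C@H]3OC(=O)c1ccc(Cl)cc1` differs from compound 3 as follows: chloro in place of nitro on an aromatic carbon. This puts chloro in place of nitro on an aromatic carbon. Among the compounds with values here, no measured pair isolates this change. The closest evidence is the swap of an alkyl group for 4-nitrophenyl on the carbonyl carbon, and both such steps, ending at compound 3 with 3300 nM, remain within the scatter. No change beyond the scatter is therefore expected in this assay, and no direction is firmly indicated. The expected size is a 1.3-fold lower number from compound 3 to compound 4 (0.12 log units; within the scatter), which lies within the scatter. For compound 4 the estimated value is 2500 nM, with an expected range of 1200 nM to 5000 nM.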

Compound 4, half-maximal inhibitory concentration: 3840 nM
Beside the measured number, compound 4's estimate is 1.5-fold (0.19 log units) below it, and the stated range covers the measured number.
By their numbers in this assay, from the lowest: compounds 2, 1, 3 and 4 (each within the scatter of the next, the first and the last beyond it).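

In this assay, within the data shown here, the step of a 1.2-fold higher number from compound 3 to compound 4 (0.07 log units; within the scatter) is the first measured pair to isolate chloro in place of nitro on an aromatic carbon para to a large group, and at this position the exchange stays within the scatter. The change of the ester group itself now reaches beyond the scatter, if only modestly, with a 2.3-fold higher number from compound 2 to compound 4 (0.37 log units; beyond the scatter) and a 2.2-fold higher number from compound 1 to compound 4 (0.35 log units; beyond the scatter) for 4-chlorophenyl in place of ethyl and methyl, whereas the matching 4-nitrophenyl steps remained within it. Nothing available explains these steps.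

Going by these compounds, it remains open whether an amine or a carboxylic acid at this ring position would move the number beyond the scatter from compound 3 or compound 4. The response of the series to a longer chain in place of ethyl on the carbonyl carbon is also unknown.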